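The source may report more compounds than this note shows. Statements on the series, on what has been measured and on what is new or still open speak of the compounds shown alone.

Working notes on the series. Compound 1 `O=C(O)c1csc([C@H]2CC[C@@H]3[C@@H](COc4cccc(F)c4)[C@H](O)C[C@@H]3O2)n1` and compound 2 `O=C(O)c1csc([C@H]2CC[C@@H]3[C@@H](COc4cccc(OC(F)(F)F)c4)[C@H](O)C[C@@H]3O2)n1` share one core and differ at the aryl ether. In an assay on HEK293 cells for agonist activity at prostaglandin E2 receptor EP2 subtype (Homo sapiens), read by a beta-galactosidase reporter and beta-arrestin recruitment, with a stated time of 90 min (a higher number here means that more compound is needed for the effect, a lower number that less compound is needed), compound 1 gives > 10000 nM; this is a limit of the assay and not a number, and compound 1 therefore sits at the limit of > 10000 nM in this assay, at which 1 of the 2 values shown sits. In this assay compound 2 gives 69 nM. Going by the values given here, the single measured step, trifluoromethoxy in place of fluoro on an aromatic carbon, reads an at least 140-fold lower number from compound 1 to compound 2 (2.16 log units; beyond the scatter).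

Compound 3 `O=C(O)c1csc([C@H]2CC[C@@H]3[C@@H](CCOc4ccccc4)[C@H](O)C[C@@H]3O2)n1` is not yet measured. Relative to compound 1 the change is phenoxymethyl in place of 3-fluorophenoxy on a saturated chain carbon bound to a saturated ring carbon. Among the compounds with values here, no measured step touches the chain length or the loss of fluoro, so the measured step from compound 1 to compound 2 bears on it only loosely. The expected step is an at least 6.6-fold lower number from compound 1 to compound 3 (0.82 log units; beyond the scatter), with wide uncertainty. Compound 3 is estimated at 1500 nM, between 150 nM and 15000 nM in this assay.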

Compound 3, half-maximal effective concentration: > 10000 nM
Compound 3: no number, only a limit (the forecaster's own chance of this, stated with the estimate: 30%); at least 6.6-fold (0.82 log units) between middle value and limit.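

Compound 1 and compound 3 both carry only a limit of the assay in this assay, so no step between them can be read: the limit of > 10000 nM in this assay, at which 2 of the 3 values shown sit.

The compounds shown leave open how far apart compound 1 and compound 3 lie, and what 2-phenoxyethyl does apart from the loss of fluoro.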